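Aminoacetamide variation on a quinoline-anilide series

The compounds below may be only part of what the source reports. "The series", "measured", "known", "first", "only" and "open" are said of these compounds alone.

Measured so far:
compound 1 `CCN(CC)CC(=O)Nc1ccc(Nc2nc3ccc(OC)cc3cc2-c2ccc(OC)cc2)cc1` — > 50000 nM
compound 2 `COc1ccc(-c2cc3cc(OC)ccc3nc2Nc2ccc(NC(=O)CN3CCCCC3)cc2)cc1` — > 50000 nM

In a functional assay on MCF7 cells (Homo sapiens) for antiproliferative activity, read by MTT assay, with a stated time of 48 h (on this read-out higher numbers stand for weaker inhibition and lower numbers for stronger inhibition), compound 1 gives > 50000 nM, which is a limit of the assay and not a number. In this assay compound 2 likewise gives > 50000 nM, again a limit. Compound 2 thus stands at the limit, with no number of its own; the step that the two limits leave unreadable from compound 1 to compound 2 stays unreadable, as both values sit at the limit (the limit of > 50000 nM in this assay, at which 2 of the 2 values shown sit).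

Compound 3 `COc1ccc(-c2cc3cc(OC)ccc3nc2Nc2ccc(NC(=O)CN3CCN(C)CC3)cc2)cc1` carries the change (4-methylpiperazin-1-yl in place of piperidin-1-yl on a saturated chain carbon bound to a carbonyl carbon). Going by the values given here, the only measured step that bears on it is a step that the two limits leave unreadable from compound 1 to compound 2, itself an exchange of one saturated amine for another on the same saturated chain carbon bound to a carbonyl carbon, and it gives no readable size. Among the compounds with values here, no measured step points to a change beyond the scatter in this assay in either direction.

Compound 3 is therefore expected in this assay at 60000 nM (range 20000 nM to 150000 nM), most likely again reported only as a limit. The expected step is a step that the limit leaves unreadable from compound 2 to compound 3, estimated as no change beyond the scatter.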

Compound 3, half-maximal inhibitory concentration: 1800 nM
Compound 3: middle estimate off by 33-fold (1.52 log units), on the high side; measured number outside the range, below it.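

In this assay, the amine on the saturated chain carbon bound to a carbonyl carbon proves to be a place where a single exchange can carry the series off the limit, with 4-methylpiperazin-1-yl in place of piperidin-1-yl giving an at least 27-fold lower number from compound 2 to compound 3 (1.44 log units; beyond the scatter). With diethylamino as the group replaced, the same entering group gives an at least 27-fold lower number from compound 1 to compound 3 (1.44 log units; beyond the scatter), so the effect appears against both of the other amines shown, while the step between those two cannot be read. Both readable steps give only a minimum size, as each starts from a compound whose value is a limit: the limit of > 50000 nM in this assay, at which 2 of the 3 values shown sit.

The compounds shown do not separate the contribution of the second ring nitrogen from that of the methyl on it; piperazin-1-yl with its free ring amine and morpholin-4-yl would bear on that question at this place. Also open, from the compounds shown here alone, is whether 4-methylpiperazin-1-yl keeps this level of activity on a longer chain between the ring and the carbonyl.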